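The compounds below may be only part of what the source reports. "The series", "measured", "known", "first", "only" and "open" are said of these compounds alone.

Of the compounds shown here, three built on one shared core have been tested in a functional assay on the whole organism (strain Swiss albino) with Mus musculus as the target, in the maximal electroshock model, with a stated time of 4 h; a lower number here means that less compound is needed, a higher number that more compound is needed for the effect. Compound 1 `C/C(=N/NC(=O)Nc1nnc(COc2ccc3ccccc3c2)o1)c1ccc(N)cc1` gives 300 mg/kg and compound 2 `C/C(=N/NC(=O)Nc1nnc(COc2ccc3ccccc3c2)o1)c1ccc(O)cc1` gives 300 mg/kg, so the step of no change at the digits printed from compound 1 to compound 2 (within the scatter) lies within the scatter. Compound 3 `O=C(N/N=C(/c1ccccc1)c1ccc([N+](=O)[O-])cc1)Nc1nnc(COc2ccc3ccccc3c2)o1` gives 300 mg/kg, level with compounds 1 and 2 at the digits shown. Compound 4 `C/C(=N/NC(=O)Nc1nnc(COc2ccc3ccccc3c2)o1)c1ccc([N+](=O)[O-])cc1` differs from compound 3 in one place: methyl in place of phenyl on a carbon with a double bond to nitrogen. Among the measured compounds shown here, no measured step exchanges these two groups at that carbon, and all three measured values sit at one level. The expectation is therefore no step beyond the scatter, and compound 4 is estimated at 300 mg/kg, with a range from 150 mg/kg to 600 mg/kg. The step of no change at the digits printed from compound 3 to compound 4 (within the scatter) is expected to stay within the scatter.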

Compound 4, minimum effective dose: 300 mg/kg
Beside the measured number, compound 4's estimate shows no gap at the digits printed; low and high end bracket the measured number.
By their numbers in this assay, from the lowest: compounds 1, 2, 3 and 4 (each within the scatter of the next).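

In this assay, among the compounds shown here, methyl in place of phenyl on a carbon with a double bond to nitrogen shows no change at the digits printed from compound 3 to compound 4 (within the scatter) and gives the first reading at that carbon. On the aromatic carbon, nitro in place of hydroxy shows no change at the digits printed from compound 2 to compound 4 (within the scatter) and nitro in place of amino shows no change at the digits printed from compound 1 to compound 4 (within the scatter) so three groups there now sit at one level. No evidence at hand bears on this result. As far as these compounds go, whether an ethyl group or a longer chain at that carbon, or a carboxylic acid on the aromatic carbon, would hold this level stays open.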